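This account rests on a few compounds, and the source may have more. Where it says the series, first, only, none or still open, it means among the compounds named here.

Series notes, solubility arm. Compound 1 `CCCOc1ccc(C[C@@H](Cc2ccccc2)C(=O)O)cc1CNC(=O)c1ccc(-c2cncnc2)cc1` is the reference point: in a physicochemical assay for solubility, read by HPLC, in phosphate buffer, measured as thermodynamic solubility, with a stated time of 48 h, at pH 7.2 (on this read-out higher numbers stand for higher solubility and lower numbers for lower solubility), compound 1 gives 190 ug/mL. Compound 2 `CCCOc1ccc(C[C@@H](Cc2ccccc2)C(=O)O)cc1CNC(=O)c1ccc(-c2ccc(F)cc2)cc1` carries a 4-fluorophenyl where compound 1 has pyrimidin-5-yl. For compound 2 this assay reports only a limit, < 1 ug/mL, so compound 2 sits at the limit of < 1 ug/mL in this assay, at which 1 of the 2 values shown sits, and no number is known for it. Within the data shown here, the one measured step, an at least 190-fold lower number from compound 1 to compound 2 (2.27 log units; beyond the scatter), is therefore itself a lower bound on the drop.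

Compound 3 `CCCOc1ccc(C[C@@H](Cc2ccccc2)C(=O)O)cc1CNC(=O)c1ccc(-c2ccccc2F)cc1` is the next member. Against compound 2 the change is 2-fluorophenyl in place of 4-fluorophenyl on an aromatic carbon. Among the measured compounds shown here, neither measured step touches this kind of change: the only step on record swaps an aromatic ring type at the same position, and it is of no direct use for moving the fluorine within the same ring. With compound 2 at a limit, the expected step of an at least 2.0-fold higher number from compound 2 to compound 3 (0.30 log units; that floor lies within the scatter) is weakly founded and is taken as small, near the scatter, with the direction uncertain. For compound 3 the estimate in this assay is 2 ug/mL, with a range from 0.6 ug/mL to 8 ug/mL, and a real chance that compound 3 also returns only a limit.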

Compound 3, solubility: < 1 ug/mL
Compound 3: a limit, no number; the forecaster's own chance of this, stated with the estimate: 45%; middle value at least 2.0-fold (0.30 log units) from the limit.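

In this assay compound 3 gives < 1 ug/mL, which is a limit and not a number. With 2-fluorophenyl in place of pyrimidin-5-yl on the same aromatic carbon, the record shows an at least 190-fold lower number from compound 1 to compound 3 (2.27 log units; beyond the scatter), so the large loss is no longer tied to the single fluorine placement in 4-fluorophenyl but holds for both fluorophenyl groups shown against the pyrimidin-5-yl of compound 1. The step between the two fluorophenyl compounds cannot be read, and moving the fluorine within the ring gives no readable value, leaving both compounds at the same limit: the limit of < 1 ug/mL in this assay, at which 2 of the 3 values shown sit.

Any real difference between 4-fluorophenyl and 2-fluorophenyl remains hidden under that limit, so neither fluorine placement can be ranked against the other. The compounds shown also leave open how much of the value of compound 1 depends on the pyrimidin-5-yl ring itself, and whether pyridin-3-yl, or a phenyl ring bearing an amine or a carboxylic acid, at this position would give a readable number between the two ends seen so far.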